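The source may hold more compounds than are shown below. What is called first, only, known or untested is meant among the compounds shown, and "the series" means these compounds.

Measured compounds:
compound 1 `CN(C)C(=O)c1cc2cnc(Nc3ccc(C(=O)NCCCCN=C=S)cc3)nc2n1C1CCCC1` with 74.2%
compound 2 `CN(C)C(=O)c1cc2cnc(Nc3ccc(C(=O)NCCCN=C=S)cc3F)nc2n1C1CCCC1` with 78.5%

Of the compounds shown here, two have been measured in a functional assay on NCI-H1299 cells (Homo sapiens) for inhibition, read by CCK-8 assay, with a stated time of 72 h, tested at 10 uM; on this read-out lower numbers stand for a weaker effect and higher numbers for a stronger effect at the one concentration tested. Compound 1 `CN(C)C(=O)c1cc2cnc(Nc3ccc(C(=O)NCCCCN=C=S)cc3)nc2n1C1CCCC1` gives 74.2%. Compound 2 `CN(C)C(=O)c1cc2cnc(Nc3ccc(C(=O)NCCCN=C=S)cc3F)nc2n1C1CCCC1` gives 78.5%, the higher of the two numbers, but its nearest neighbour, compound 1, lies within the scatter of repeated measurements, so the two cannot be told apart on this read-out. Going by the values given here, no single-point step between the measured compounds is available: compound 1 and compound 2 differ in more than one place.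

Compound 3 `CN(C)C(=O)c1cc2cnc(Nc3ccc(C(=O)NCCCCN=C=S)cc3F)nc2n1C1CCCC1` has not yet been measured. It differs from compound 2 by a group of 4 heavy atoms (2 carbon, 1 nitrogen, 1 sulfur; no ring) in place of a group of 3 heavy atoms (1 carbon, 1 nitrogen, 1 sulfur; no ring), on a saturated chain carbon, three bonds along the chain from an amide-type nitrogen.

Compound 1 carries the same chain as compound 3. Because compound 2 gives 78.5% and compound 1 gives 74.2%, the expectation is that the change from compound 2 to compound 3 produces no step beyond the scatter in this assay, in either direction. Compound 3 is therefore estimated to give 76% in this assay, within a range from 62% to 88%, which corresponds to an expected step of a number 2.5 percentage points lower from compound 2 to compound 3 (within the scatter).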

Compound 3, a percentage reported as inhibition, at one concentration (the size of the read-out at that concentration, not a potency): 78.9%
Compound 3: the middle estimate sits 2.9 percentage points below what was measured; low and high end bracket the measured number.
By their numbers in this assay, from the lowest: compounds 1, 2 and 3 (each within the scatter of the next).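

In this assay, a group of 4 heavy atoms (2 carbon, 1 nitrogen, 1 sulfur; no ring) in place of a group of 3 heavy atoms (1 carbon, 1 nitrogen, 1 sulfur; no ring), on a saturated chain carbon, three bonds along the chain from an amide-type nitrogen, gives a number 0.4 percentage points higher from compound 2 to compound 3 (within the scatter) on this read-out, so the two groups cannot be told apart at this place when the fluoro is present. Fluoro in place of hydrogen on an aromatic carbon gives a number 4.7 percentage points higher from compound 1 to compound 3 (within the scatter) in the same read-out, which is likewise no measurable change at the one concentration tested. Nothing available bears on what lies behind these two small steps.

On these data alone, whether a carboxylic acid, an amine or a longer chain at this place would keep the number in the same range remains open. As far as these compounds go, because all three compounds were read at a single concentration, their potencies also remain open, and any difference among them that a full concentration series might reveal cannot be judged from this assay alone.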